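This account rests on a few compounds, and the source may have more. Where it says the series, first, only, none or still open, it means among the compounds named here.

Measured compounds and their values:
- compound 1 `O=C(Nc1cccc(/C=C/C(=O)c2nc3ccccc3[nH]2)c1)c1cccc(Cl)c1`: 1120 nM
- compound 2 `Cc1cccc(C(=O)Nc2cccc(/C=C/C(=O)c3nc4ccccc4[nH]3)c2)c1`: 1420 nM

In a functional assay on HCT-116 cells (Homo sapiens) for antiproliferative activity, read by MTT assay, with a stated time of 48 h (on this read-out lower numbers stand for stronger inhibition and higher numbers for weaker inhibition), compound 1 and compound 2 cannot be told apart: the step of a 1.3-fold higher number from compound 1 to compound 2 (0.10 log units; within the scatter) is the only one so far, and it changes nothing beyond the scatter. Compound 3 `O=C(Nc1cccc(/C=C/C(=O)c2nc3ccccc3[nH]2)c1)c1cccc(C(F)(F)F)c1` is reached from compound 1 by one change: trifluoromethyl in place of chloro on an aromatic carbon. Among the measured compounds shown here, the one measured step that bears on it swaps the same chloro for a different small group on the same ring, and that swap left the read-out essentially unchanged. There is no measurement of trifluoromethyl at this place, so the expectation rests on that single step alone. A step of no more than the usual scatter is therefore expected here, with no direction favoured; the expected step is a 1.1-fold higher number from compound 1 to compound 3 (0.03 log units; within the scatter). For compound 3 the estimate is 1200 nM, with a range from 600 nM to 2400 nM.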

Compound 3, half-maximal inhibitory concentration: 3360 nM
Estimate against measurement, compound 3: 2.8-fold (0.45 log units) below; measured number outside the range, above it.
By their numbers in this assay, from the lowest: compounds 1 and 2 (each within the scatter of the next); then compound 3.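

In this assay this position does not accept every small group equally: trifluoromethyl in place of chloro gives a 3.0-fold higher number from compound 1 to compound 3 (0.48 log units; beyond the scatter) and trifluoromethyl in place of methyl gives a 2.4-fold higher number from compound 2 to compound 3 (0.37 log units; beyond the scatter) on the same read-out, and both steps point to weaker inhibition. The chloro and methyl pair alone could have suggested a place where swaps make no difference, but compound 3 shows that the group here can change the result, if only modestly. Trifluoromethyl has four heavy atoms against one for chloro, yet nothing at hand explains the weaker inhibition.

Going by these compounds, how an amine, a methoxy group or a carboxylic acid would read at this place remains open. So does whether trifluoromethyl would give a similar step elsewhere on this ring.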